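The source may hold more compounds than are shown below. What is called first, only, known or untested is meant among the compounds shown, and "the series" means these compounds.

Results in a toxicity assay on MT2 cells (Homo sapiens) for cytotoxicity, read by XTT assay, with a stated time of 4 days (on this read-out higher numbers stand for lower toxicity in this test and lower numbers for higher toxicity in this test), for the three compounds tested so far
Compound 1 `Cc1ccc(-c2ccc(C(=O)N[C@H](c3nc(C)c(CCO)s3)[C@@H]3CCCCN3)[nH]2)cc1F` gives 29700 nM
Compound 2 `Cc1nc([C@@H](NC(=O)c2ccc(-c3ccc(Cl)c(F)c3)[nH]2)[C@@H]2CCCCN2)sc1CCO` gives 16900 nM
Compound 3 `Cc1nc([C@H](NC(=O)c2ccc(-c3ccc(Cl)c(F)c3)[nH]2)[C@@H]2CCCCN2)sc1CCO` gives 16800 nM

Compound 2 at 16900 nM stands within the scatter of both other compounds, so the three cannot be ranked. Compound 4 `Cc1nc([C@@H](NC(=O)c2ccc(-c3ccc(Cl)cc3)[nH]2)[C@@H]2CCCCN2)sc1CCO` has not yet been measured. It differs from compound 2 by hydrogen in place of fluoro on an aromatic carbon, which turns 4-chloro-3-fluorophenyl into 4-chlorophenyl.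

Going by the values given here, no measured step makes this exact swap. The nearest guide is chloro in place of methyl on an aromatic carbon (a 1.8-fold lower number from compound 1 to compound 2 (0.24 log units; within the scatter)), which stayed within the scatter. The change of configuration (a 1.0-fold lower number from compound 2 to compound 3 (0.00 log units; within the scatter)) also stayed within the scatter, but it bears only loosely on a swap of groups because of the fact that compounds 2 and 3 differ only in the configuration as drawn and so adds little. With only these two small steps as a guide, no step beyond the scatter is expected in this assay in either direction. The estimate therefore means a 1.1-fold higher number from compound 2 to compound 4 (0.03 log units; within the scatter) as an expected step, resting on compound 2 at 16900 nM as the starting point. For compound 4 the estimated value is 18000 nM with an expected range from 9500 nM to 34000 nM in this test.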

Compound 4, half-maximal cytotoxic concentration: 26800 nM
Beside the measured number, compound 4's estimate is 1.5-fold (0.17 log units) below it; low and high end bracket the measured number.
By their numbers in this assay, from the lowest: compounds 3, 2, 4 and 1 (each within the scatter of the next).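

In this assay, going by these compounds alone, taking the fluoro off the 4-chloro-3-fluorophenyl group to leave 4-chlorophenyl gives a 1.6-fold higher number from compound 2 to compound 4 (0.20 log units; within the scatter), the first direct reading of this position on the six-membered aromatic ring, ortho to the chloro group. Losing that single heavy atom there therefore produces no step beyond the scatter, and the read-out cannot tell the fluoro from hydrogen at this place. The broader swap of 3-fluoro-4-methylphenyl for 4-chlorophenyl gives a 1.1-fold lower number from compound 1 to compound 4 (0.04 log units; within the scatter), so this group as a whole has so far been changed in more than one place without a clear shift, and no measurement shown here bears on why the numbers stay so close.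

As far as these compounds go, whether a different kind of group at this position, such as methoxy, nitrile or an amine, would move the number beyond the scatter remains open, since only fluoro and hydrogen have been compared there. It is also open whether the same swap would behave alike in the configuration of compound 3, which has only the 4-chloro-3-fluorophenyl group among the compounds shown.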